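The compounds below may be only part of what the source reports. "The series", "measured", "known", "first", "only" and "open" are said of these compounds alone.

Compound 1 `COc1c(OC(C)C)cc2oc(-n3cncn3)c(-c3csc4ccccc34)c(=O)c2c1OC(C)C`: > 10000 nM
Compound 2 `COc1cc(O)c(C(=O)/C=C/c2csc3ccccc23)c(OC)c1OC`: 7700 nM
Compound 3 `COc1c(OC(C)C)cc2c(c1OC(C)C)C(=O)/C(=C/c1csc3ccccc13)O2`: > 10000 nM

These results come from a functional assay on MCF7 cells (Homo sapiens) for antiproliferative activity, read by sulforhodamine B assay, with a stated time of 72 h; on this read-out lower numbers stand for stronger inhibition and higher numbers for weaker inhibition. Compound 3 gives > 10000 nM, which is a limit of the assay and not a number. Compound 1 gives > 10000 nM, which is also a limit. The two compounds therefore share (the limit of > 10000 nM in this assay, at which 2 of the 3 values shown sit). Only compound 2 has a true number, 7700 nM.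

Compound 4 `COc1c(OC(C)C)cc2c(c1O)C(=O)/C(=C/c1csc3ccccc13)O2` is a close relative of compound 3, and the change is simple: hydrogen in place of isopropyl on an oxygen on an aromatic ring. In words, isopropoxy becomes hydroxy, with hydrogen in place of isopropyl on an oxygen on an aromatic ring. Among the measured compounds shown here, no measured pair shows this change directly, so any forecast is uncertain. For the measured compounds named here, the only hint is that compound 2, which also has a hydroxy group on an aromatic ring, gives 7700 nM. A modest move toward lower numbers in this assay is therefore expected, and another limit would not be surprising. The expected change is an at least 2.0-fold lower number from compound 3 to compound 4 (0.30 log units; that floor lies within the scatter). The estimated value for compound 4 is 5000 nM, within an expected range of 1200 nM to 20000 nM.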

Compound 4, half-maximal inhibitory concentration: > 10000 nM
Compound 4: a limit, no number (the forecaster's own chance of this, stated with the estimate: 35%); middle value at least 2.0-fold (0.30 log units) from the limit.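

Compound 3 and compound 4 both sit at a limit of the assay and not at a number, so no step between them can be read: the limit of > 10000 nM in this assay, at which 3 of the 4 values shown sit.

The compounds shown leave open whether isopropoxy to hydroxy changes the activity of this core at all.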